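Swapping a Short Branch for a Phenylpropyl Chain

This account rests on a few compounds, and the source may have more. Where it says the series, first, only, none or still open, it means among the compounds named here.

Of the compounds shown here, two have been measured in an assay on HEK293 cells for inhibition of acid ceramidase (Homo sapiens), read by fluorescence, with stated times of 10 min and 3 h; a lower number here means a stronger inhibitor, a higher number a weaker inhibitor. Compound 1, with structure `CN1CCC(c2ccc3c(c2)oc(=O)n3C(=O)NCCCCc2ccccc2)CC1=O`, gives 105 nM. Compound 2, with structure `CC(C)CNC(=O)n1c(=O)oc2cc(C3CCN(C)CC3)ccc21`, gives 166 nM. Of these two numbers, compound 2 has the higher one, but the gap to compound 1 is within the usual scatter, so the two compounds cannot be told apart on this evidence.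

Compound 3, with structure `CN1CCC(c2ccc3c(c2)oc(=O)n3C(=O)NCCCCc2ccccc2)CC1`, has not yet been measured. It differs from compound 2 in one place: 3-phenylpropyl in place of isopropyl on a saturated chain carbon bound to an amide-type nitrogen. For the measured compounds named here, compound 1 carries the same 4-phenylbutyl chain as compound 3, but differs from it elsewhere, so no single step links compound 1 to compound 3 and its value can only serve as a rough pointer.

Going by the values given here, since no measured step for this change exists, the expectation rests on compound 1 and compound 2 alone. A modest improvement is expected, though a result within the scatter would not be surprising. The step is estimated as a 2.4-fold lower number from compound 2 to compound 3 (0.38 log units; beyond the scatter). Compound 3 is expected to give about 70 nM in this assay, with a range from 20 nM to 250 nM.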

Compound 3, half-maximal inhibitory concentration: 129 nM
For compound 3 the middle estimate is 1.8-fold (0.27 log units) below the measured one; low and high end bracket the measured number.
By their numbers in this assay, from the lowest: compounds 1, 3 and 2 (each within the scatter of the next).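

In this assay, the change from isobutyl to 4-phenylbutyl, read as 3-phenylpropyl in place of isopropyl on a saturated chain carbon bound to an amide-type nitrogen, is a 1.3-fold lower number from compound 2 to compound 3 (0.11 log units; within the scatter). A short branched chain and a long chain ending in an aromatic ring therefore cannot be told apart at this position, so adding the ring and the extra chain carbons brings no measurable gain here. The second step, 1-methylpiperidin-4-yl in place of 1-methyl-2-oxopiperidin-4-yl on an aromatic carbon, is a 1.2-fold higher number from compound 1 to compound 3 (0.09 log units; within the scatter), which shows that with the 4-phenylbutyl chain held fixed, the ring carbonyl also makes no difference that can be distinguished from the scatter.

These compounds leave open whether any group at the chain position can move the number beyond the scatter, such as a chain ending in an amine or a carboxylic acid, or a much shorter ethyl group. From the compounds shown here alone, it also remains open whether a piperidine with no methyl group on its nitrogen would behave like the two rings seen so far. No measurement is available that would explain either result.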